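This account rests on a few compounds, and the source may have more. Where it says the series, first, only, none or still open, it means among the compounds named here.

Measured so far in an ADME assay on HPLF cells (Homo sapiens) for cytotoxicity, with a stated time of 24 h; on this read-out higher numbers stand for lower toxicity in this test and lower numbers for higher toxicity in this test
compound 1 `CN(C)c1ccc(/C=C2\CCC/C(=C\c3ccccc3[N+](=O)[O-])C2=O)cc1` > 400000 nM (a limit of the assay)
compound 2 `O=C1/C(=C/c2ccccc2)CCC/C1=C\c1cccc([N+](=O)[O-])c1` 18000 nM
compound 3 `O=C1/C(=C/c2ccc(F)cc2)CCC/C1=C\c1cccc([N+](=O)[O-])c1` 36000 nM

Within the data shown here, compound 3 at 36000 nM is one of only two true numbers, and it lies within the scatter of compound 2. Compound 1 sits at the limit of > 400000 nM in this assay, at which 1 of the 3 values shown sits, which is a limit and not a number.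

Next is compound 4 `CN(C)c1ccc(/C=C2\CCC/C(=C\c3cccc([N+](=O)[O-])c3)C2=O)cc1`. Its difference from compound 3 is dimethylamino in place of fluoro on an aromatic carbon, para to a large group.

Among the measured compounds shown here, the one measured single-site step is a 2.0-fold higher number from compound 2 to compound 3 (0.30 log units; within the scatter). It replaces hydrogen with fluoro and stays within the scatter, so it gives little guidance on the size of a change to dimethylamino. For the measured compounds named here, the only measured compound with a dimethylamino group is compound 1, at > 400000 nM, a limit. On that single compound, a step beyond the scatter towards a higher number is expected in this assay. With so little support, its size remains loosely set and the range is wide.

The estimated step is a 3.3-fold higher number from compound 3 to compound 4 (0.52 log units; beyond the scatter). For compound 4 the expected value is 120000 nM, with an estimated range of 30000 nM to 400000 nM.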

Compound 4, half-maximal cytotoxic concentration: > 400000 nM
Compound 4 ended at the assay's limit (the forecaster's own chance of this, stated with the estimate: 35%); middle value at least 3.3-fold (0.52 log units) from the limit.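

In this assay, the change at this position now gives a step beyond the scatter: an at least 11-fold higher number from compound 3 to compound 4 (1.04 log units; beyond the scatter), with dimethylamino replacing fluoro on the same ring. The comparison with hydrogen at this place points the same way, an at least 22-fold higher number from compound 2 to compound 4 (1.34 log units; beyond the scatter), whereas a 2.0-fold higher number from compound 2 to compound 3 (0.30 log units; within the scatter) stays within the scatter, so among these three compounds only dimethylamino separates from the others at this site. Compound 1 and compound 4, the two compounds carrying dimethylamino, both stand at a limit of the assay and not at a number, so the step between them cannot be read, and no compound shown goes against the link between this group and the limit.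

As far as these compounds go, the full size of the dimethylamino step and any effect of moving the nitro group between the two nitrophenyl arrangements remain open: the limit of > 400000 nM in this assay, at which 2 of the 4 values shown sit. Whether the same step holds for a primary amine, a methoxy group or a morpholine at this place, which would show if it is particular to dimethylamino, cannot be told from the compounds shown.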